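This account rests on a few compounds, and the source may have more. Where it says the series, first, only, none or still open, it means among the compounds named here.

Two compounds share a core and differ only in the group attached to the sulfonyl sulfur. Compound 1 `O=S(=O)(Nc1ccc(-c2nc3ccccc3o2)cc1)c1ccc(Cl)s1` carries 5-chlorothiophen-2-yl there, and in an assay on cells for inhibition of HSP60/HSP10 (Homo sapiens), with a stated time of 60 min (a lower number here means a stronger inhibitor, a higher number a weaker inhibitor), compound 1 gives 31000 nM. Compound 2 `O=S(=O)(Nc1ccc(-c2nc3ccccc3o2)cc1)c1cccc(O)c1` carries 3-hydroxyphenyl instead, and in this assay compound 2 gives 62000 nM. That exchange made a 2.0-fold higher number from compound 1 to compound 2 (0.30 log units; within the scatter), so the two measured values cannot be told apart. For the measured compounds named here, compound 2 therefore stands as the higher of the two numbers, with compound 1 as its only neighbour.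

Compound 3 `CS(=O)(=O)Nc1ccc(-c2nc3ccccc3o2)cc1` continues along the same line: methyl in place of 3-hydroxyphenyl on a sulfonyl sulfur. Going by the values given here, the one measured step that bears on this place, a 2.0-fold higher number from compound 1 to compound 2 (0.30 log units; within the scatter), lay within the scatter, so only a small shift is expected here, with no strong direction. Compound 3 is expected to give 80000 nM, within a range from 30000 nM to 200000 nM, which would mean a 1.3-fold higher number from compound 2 to compound 3 (0.11 log units; within the scatter).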

Compound 3, half-maximal inhibitory concentration: > 100000 nM
Compound 3: no number, only a limit; the forecaster's own chance of this, stated with the estimate: 30%; at least 1.2-fold (0.09 log units) between middle value and limit.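

The reading for compound 3 is a limit of the assay and not a number: the limit of > 100000 nM in this assay, at which 1 of the 3 values shown sits.

Even so, this position now shows a change that can be read, with an at least 3.2-fold higher number from compound 1 to compound 3 (0.50 log units; beyond the scatter), the first step at the sulfonyl sulfur to lie beyond the scatter. Against the 3-hydroxyphenyl group the floor is smaller, an at least 1.6-fold higher number from compound 2 to compound 3 (0.20 log units; that floor lies within the scatter), so that comparison alone does not separate the two compounds, and among these three only the compounds with a ring on the sulfonyl sulfur give a measured number.

Going by these compounds, how far compound 3 lies past its limit stays open. Also open, on these data alone, is whether a ring is needed at this place, or whether a longer chain such as butyl, or a plain phenyl, would give a measurable number in this assay.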